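Alpha-methyl on the benzylamine of a diaryl ether series

The source may report more compounds than this note shows. Statements on the series, on what has been measured and on what is new or still open speak of the compounds shown alone.

Three measured compounds share one core and differ only in the group carried by the amine. Compound 1 `COc1cc(Oc2cccc(Nc3ccccc3)c2)cc(OC)c1CNCc1ccccc1` gives 4070 nM in a functional assay on HCT-116 cells (Homo sapiens) for inhibition, read by MTT assay, with a stated time of 72 h; a higher number here means a weaker inhibitor, a lower number a stronger inhibitor. Compound 2 `COc1cc(Oc2cccc(Nc3ccccc3)c2)cc(OC)c1CNCc1ccc(F)cc1` gives 4220 nM, and the fluoro step is flat: a 1.0-fold higher number from compound 1 to compound 2 (0.02 log units; within the scatter). Compound 3 `COc1cc(Oc2cccc(Nc3ccccc3)c2)cc(OC)c1CNCCNC(C)=O` gives 18200 nM, a loss of a 4.5-fold higher number from compound 1 to compound 3 (0.65 log units; beyond the scatter) when the aromatic group is traded for acetamidomethyl. Compound 1 therefore sits at the low end of the three numbers, separated from compound 3 beyond the scatter but not from compound 2.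

Compound 4 `COc1cc(Oc2cccc(Nc3ccccc3)c2)cc(OC)c1CN[C@H](C)c1ccccc1` is compound 1 carrying (methyl in place of hydrogen on a saturated chain carbon bound to an amine nitrogen and an aromatic carbon), so the benzyl becomes 1-phenylethyl and the phenyl is kept. The step from compound 1 to compound 2 shows that a small addition around the benzyl group leaves the number unchanged; the step from compound 1 to compound 3 shows that removing the phenyl costs a modest amount. Within the data shown here, no measured step probes a substituent on the chain carbon itself, so the nearest evidence argues for retention of the phenyl and a step within the scatter. He expects compound 4 to give 4500 nM, within 2000 nM to 10000 nM, a step of a 1.1-fold higher number from compound 1 to compound 4 (0.04 log units; within the scatter).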

Compound 4, half-maximal inhibitory concentration: > 20000 nM
Compound 4 was reported as a limit; the forecaster's own chance of this, stated with the estimate: 3%; middle value at least 4.4-fold (0.64 log units) away from the limit.
By their numbers in this assay, from the lowest: compounds 1 and 2 (each within the scatter of the next); then compound 3. At a limit, above all of these: compound 4.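

Compound 4 is reported only as a limit in this assay: the limit of > 20000 nM in this assay, at which 1 of the 4 values shown sits. With the phenyl kept, methyl in place of hydrogen on the saturated chain carbon bound to an amine nitrogen and an aromatic carbon produces an at least 4.9-fold higher number from compound 1 to compound 4 (0.69 log units; beyond the scatter), so retaining the aromatic group does not secure the number, and this chain carbon responds to the addition of a single carbon in a way the fluoro on the ring did not, that change giving a 1.0-fold higher number from compound 1 to compound 2 (0.02 log units; within the scatter). The comparison with the fluorinated benzyl compound agrees, with an at least 4.7-fold higher number from compound 2 to compound 4 (0.67 log units; beyond the scatter), while an at least 1.0-fold higher number from compound 3 to compound 4 (0.04 log units; that floor lies within the scatter) is only a floor, so that pair cannot be placed in order.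

How far past the limit compound 4 lies remains open, as does whether the loss goes with the methyl as such or with its configuration, since only one stereoisomer of the 1-phenylethyl compound appears among those shown. The compounds shown also leave open how an ethyl or a hydroxymethyl on this chain carbon, or a methyl on the amine nitrogen itself, would read.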